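Methyl on the hydroxy oxygen of compound 3

The source may report more compounds than this note shows. Statements on the series, on what has been measured and on what is new or still open speak of the compounds shown alone.

In a functional assay on MDA-MB-231 cells (Homo sapiens) for cytotoxicity, read by sulforhodamine B assay, with a stated time of 3 days (on this read-out higher numbers stand for an effect only at larger amounts of compound and lower numbers for an effect already at smaller amounts), compound 3 `Cc1coc(-c2ccc3c(c2O)CCCC3(C)C)c1CO` gives 39.5 uM. Compound 1 `CCOCc1c(C)coc1-c1ccc2c(c1OC)CCCC2(C)C` gives 42.7 uM and compound 2 `Cc1coc(-c2ccc3c(c2O)CCCC3(C)C)c1C(=O)O` gives 24.7 uM, so compound 3 sits among three numbers that all lie within the usual scatter of one another.

Compound 4 `COc1c(-c2occ(C)c2CO)ccc2c1CCCC2(C)C` differs from compound 3 by one change: methyl in place of hydrogen on an oxygen on an aromatic ring. This is methyl in place of hydrogen on an oxygen on an aromatic ring, or hydroxy to methoxy.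

Among the compounds with values here, the only measured step, a 1.6-fold higher number from compound 2 to compound 3 (0.20 log units; within the scatter), concerns another place, where hydroxymethyl stands in place of carboxy on an aromatic carbon. Within the data shown here, no measured pair isolates the new change, so its size is not known directly. Compound 1 also carries the methoxy, though it differs elsewhere too, and its 42.7 uM is close to the value of compound 3.

The expected step is a 1.0-fold higher number from compound 3 to compound 4 (0.01 log units; within the scatter), which means none beyond the scatter. For compound 4 the estimated value is 40 uM, with an expected range from 20 uM to 80 uM.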

Compound 4, concentration for half-maximal effect: 28.3 uM
Compound 4: middle estimate off by 1.4-fold (0.15 log units), on the high side; low and high end bracket the measured number.
By their numbers in this assay, from the lowest: compounds 2, 4, 3 and 1 (each within the scatter of the next).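

The hydroxy to methoxy change now has a direct reading in this assay and putting methyl in place of hydrogen on this oxygen gives a 1.4-fold lower number from compound 3 to compound 4 (0.14 log units; within the scatter) so the number at this position does not move beyond the scatter. A second place can also be read, where hydrogen in place of ethyl on an oxygen on a saturated carbon gives a 1.5-fold lower number from compound 1 to compound 4 (0.18 log units; within the scatter) and this step also stays within the scatter. Nothing measured here offers a reason for these two results.

Going by these compounds, whether a longer chain such as propyl on the aromatic oxygen, or an amine in place of the hydroxy, would move the number beyond the scatter remains open. Because both steps stay so small, these compounds also do not show which places on the shared core, if any, matter in this assay.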